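Stripping the methoxy groups from compound 3

The compounds below may be only part of what the source reports. "The series", "measured", "known", "first", "only" and "open" are said of these compounds alone.

For the measured compounds named here, in a functional assay on ECa-109 cells (Homo sapiens) for cytotoxicity, read by MTT assay, with a stated time of 72 h (on this read-out higher numbers stand for weaker inhibition and lower numbers for stronger inhibition), compound 3 (`COc1cccc(C=C2C(=O)N(c3ccc(Cl)cc3)N(c3ccc(Cl)cc3)C2=O)c1OC`) gives 6800 nM, the lowest number so far. Compound 1 (`COc1cccc(C=C2C(=O)N(c3ccc(Cl)cc3)N(c3ccc(Cl)cc3)C2=O)c1`) gives 29000 nM. Compound 2 (`COc1ccc(C=C2C(=O)N(c3ccc(Cl)cc3)N(c3ccc(Cl)cc3)C2=O)cc1OC`) gives > 128000 nM, which is a limit. Compound 4 (`O=C1C(=Cc2ccccc2)C(=O)N(c2ccc(Cl)cc2)N1c1ccc(Cl)cc1`) brings (phenyl in place of 2,3-dimethoxyphenyl on a double-bonded chain carbon bound to a double-bonded ring carbon), so phenyl replaces 2,3-dimethoxyphenyl.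

Methoxy steps point both ways: a 4.3-fold lower number from compound 1 to compound 3 (0.63 log units; beyond the scatter), but an at least 4.4-fold higher number from compound 1 to compound 2 (0.64 log units; beyond the scatter). Placement also matters, with an at least 18-fold lower number from compound 2 to compound 3 (1.27 log units; beyond the scatter). Loss of the methoxy groups should therefore give up the advantage of compound 3, leaving a number nearer that of compound 1 at 29000 nM. A modest rise in this assay is expected, estimated as a 4.0-fold higher number from compound 3 to compound 4 (0.60 log units; beyond the scatter). The estimate for compound 4 is 27000 nM, with an expected range of 8000 nM to 90000 nM.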

Compound 4, half-maximal inhibitory concentration: 32700 nM
Estimate against measurement, compound 4: 1.2-fold (0.08 log units) below; measured number inside the range.
By their numbers in this assay, from the lowest: compound 3; then compounds 1 and 4 (each within the scatter of the next). At a limit, above all of these: compound 2.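

Going to the plain phenyl gives a 4.8-fold higher number from compound 3 to compound 4 (0.68 log units; beyond the scatter), so the advantage of compound 3 belongs to the 2,3-dimethoxyphenyl group and not to the shared core alone. For the compounds shown here, the single methoxy of compound 1 does not separate from phenyl, with a 1.1-fold higher number from compound 1 to compound 4 (0.05 log units; within the scatter), while replacing 3,4-dimethoxyphenyl gives an at least 3.9-fold lower number from compound 2 to compound 4 (0.59 log units; beyond the scatter), so that methoxy pair costs activity relative to phenyl. Compound 2 is held at a limit: the limit of > 128000 nM in this assay, at which 1 of the 4 values shown sits.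

On these data alone, whether a hydroxyl or an amine in place of the methoxy groups of 2,3-dimethoxyphenyl would keep the low number of compound 3 remains open.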